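Compound 2 to compound 3: a hydroxy group enters

A few compounds are considered here, and "the series" means these few. Any claim that something is new, unique, unknown or untested is made for them only; others in the source may bear on it.

Measured so far in an assay on cells for inhibition of Indoleamine 2,3-dioxygenase 1 (Homo sapiens), read by HPLC, with a stated time of 20 min; on this read-out lower numbers stand for stronger inhibition and higher numbers for weaker inhibition:
compound 1, `Clc1cccc(-c2cnc[nH]2)c1`: 2600 nM
compound 2, `Cn1cncc1-c1cccc(Cl)c1`: 12900 nM

Compound 2 stands highest of the two numbers; its nearest neighbour is compound 1, and the step of a 5.0-fold higher number from compound 1 to compound 2 (0.70 log units; beyond the scatter), methyl in place of hydrogen on an aromatic nitrogen, is modest but beyond the scatter. Compound 3, `Cn1cncc1-c1cc(Cl)ccc1O`, differs from compound 2 by hydroxy in place of hydrogen on an aromatic carbon. Going by the values given here, no measured pair carries this change, and the single known step concerns a different position and a different group, so it gives no guide to the size or direction of the new step in this assay. Without a bearing step, no movement beyond the scatter is expected, and the range is set wide. The step of a 1.3-fold lower number from compound 2 to compound 3 (0.11 log units; within the scatter) is therefore the estimated outcome, with compound 3 expected at 10000 nM, between 2500 nM and 40000 nM.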

Compound 3, half-maximal inhibitory concentration: 17000 nM
The estimate for compound 3 lay 1.7-fold (0.23 log units) below the measured number; the range from low to high includes it.
By their numbers in this assay, from the lowest: compound 1; then compounds 2 and 3 (each within the scatter of the next).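

In this assay the hydroxy group on this aromatic carbon, ortho to a group of 6 heavy atoms and para to the chloro group, gives a 1.3-fold higher number from compound 2 to compound 3 (0.12 log units; within the scatter) and so no change beyond the scatter. At this position and on this N-methyl background, the added hydrogen-bond donor and acceptor therefore leave the read-out within the scatter, which the step on the aromatic nitrogen could not indicate. Nothing available explains why this substitution leaves the number within the scatter.

On these data alone, whether hydroxy behaves the same way on compound 1, which keeps the hydrogen on the aromatic nitrogen, remains open. Also open, as far as these compounds go, is how a methoxy group, an amine or a carboxylic acid at this carbon would read, and whether hydroxy would give a similar step on the other ring carbons.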